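The source may hold more compounds than are shown below. What is called first, only, known or untested is meant among the compounds shown, and "the series" means these compounds.

Measured so far:
compound 1 `C[C@@H](O[C@H]1CN2C(=O)C=C(c3ccc(C#N)cc3)CC2[C@@H]1c1ccc(F)cc1)c1cc(C(F)(F)F)cc(C(F)(F)F)c1`, 53 nM
compound 2 `C[C@@H](O[C@H]1CN2C(=O)C=C(c3ccncc3)CC2[C@@H]1c1ccc(F)cc1)c1cc(C(F)(F)F)cc(C(F)(F)F)c1`, 8.1 nM
compound 3 `C[C@@H](O[C@H]1CN2C(=O)C=C(c3cc[n+]([O-])cc3)CC2[C@@H]1c1ccc(F)cc1)c1cc(C(F)(F)F)cc(C(F)(F)F)c1`, 2.1 nM

In an assay on CHO cells for displacement of a labelled ligand from Substance-P receptor (Homo sapiens), in the presence of a further agent that is not named here (a higher number here means a weaker inhibitor, a lower number a stronger inhibitor), compound 1 gives the highest of the three numbers, so it is the weakest inhibitor of the set. Compound 4 `C[C@@H](O[C@H]1CN2C(=O)C=C(c3ccc[n+]([O-])c3)CC2[C@@H]1c1ccc(F)cc1)c1cc(C(F)(F)F)cc(C(F)(F)F)c1` differs from compound 1 in one place: a group of 7 heavy atoms (5 carbon, 1 nitrogen, 1 oxygen; one six-membered aromatic ring with 1 hetero atom) in place of a group of 8 heavy atoms (7 carbon, 1 nitrogen; one six-membered aromatic ring of carbon only), on a double-bonded ring carbon. The entering group has the same atom count as that of compound 3, arranged differently on its ring. Among the compounds with values here, two measured steps bear on this change: a 6.5-fold lower number from compound 1 to compound 2 (0.82 log units; beyond the scatter) and a 25-fold lower number from compound 1 to compound 3 (1.40 log units; beyond the scatter), and between those two, a 3.9-fold lower number from compound 2 to compound 3 (0.59 log units; beyond the scatter). Both replacements of the 4-cyanophenyl lowered the number well beyond the scatter, so a clearly lower number is expected for compound 4 too, estimated as a 12-fold lower number from compound 1 to compound 4 (1.07 log units; beyond the scatter). Compound 4 is therefore expected to give about 4.5 nM in this assay, within 1.5 nM to 14 nM.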

Compound 4, half-maximal inhibitory concentration: 2.3 nM
Compound 4: middle estimate off by 2.0-fold (0.29 log units), on the high side, and the stated range covers the measured number.
By their numbers in this assay, from the lowest: compounds 3 and 4 (each within the scatter of the next); then compound 2; then compound 1.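

In this assay the new group gives a 23-fold lower number from compound 1 to compound 4 (1.36 log units; beyond the scatter) and also a 3.5-fold lower number from compound 2 to compound 4 (0.55 log units; beyond the scatter) so the low number of compound 3 does not depend on a single arrangement of these atoms on the ring. Rearranging them gives a 1.1-fold higher number from compound 3 to compound 4 (0.04 log units; within the scatter) which means this assay does not separate the two arrangements. No measurement at hand explains these results.

Still open, going by these compounds, is whether a phenyl ring carrying an amine or a carboxylic acid in place of the nitrile would also reach such low numbers at this double-bonded ring carbon.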